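This account rests on a few compounds, and the source may have more. Where it says the series, first, only, none or still open, it means among the compounds named here.

Compound 1 `COc1cccc(/C=C/C(=O)c2ccc(OC)c3c2OC(C)(C)C=C3)c1` gives in a functional assay on K562 cells (Homo sapiens) for antiproliferative activity, read by MTT assay, with a stated time of 24 h; a lower number here means a stronger inhibitor, a higher number a weaker inhibitor > 10000 nM, which is a limit of the assay and not a number.
Compound 2 `COc1ccc(/C=C/C(=O)c2ccc(OC)c3c2OC(C)(C)C=C3)c(F)c1` gives > 10000 nM, likewise a limit.
Compound 3 `COc1ccc(C(=O)/C=C/c2ccc(N(C)C)cc2)c2c1C=CC(C)(C)O2` gives 3500 nM.

Compound 3 thus holds the only number among the three shown, the other two values being limits. Compound 4 `COc1ccc(C(=O)/C=C/c2ccc(-n3ccnc3)cc2)c2c1C=CC(C)(C)O2` differs from compound 3 by 1H-imidazol-1-yl in place of dimethylamino on an aromatic carbon. Going by the values given here, no measured step changes this group; the nearest steps exchange one aryl for another on the double-bonded chain carbon, namely an at least 2.8-fold lower number from compound 1 to compound 3 (0.45 log units; beyond the scatter) and an at least 2.8-fold lower number from compound 2 to compound 3 (0.45 log units; beyond the scatter), both at least modest and with their full size left open by the limit of > 10000 nM in this assay, at which 2 of the 3 values shown sit. Neither speaks to an imidazolyl, so the direction rests on little; compound 4 is nonetheless expected to come out weaker, the step from compound 3 estimated as a 2.3-fold higher number from compound 3 to compound 4 (0.36 log units; beyond the scatter). Compound 4 is accordingly estimated at 8000 nM, between 2500 nM and 30000 nM.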

Compound 4, half-maximal inhibitory concentration: > 10000 nM
Compound 4 was reported as a limit; the forecaster's own chance of this, stated with the estimate: 45%; middle value at least 1.2-fold (0.09 log units) from the limit.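

In this assay, 1H-imidazol-1-yl in place of dimethylamino on this aromatic carbon gives an at least 2.8-fold higher number from compound 3 to compound 4 (0.45 log units; beyond the scatter), the only step shown that changes this group itself. The 1H-imidazol-1-yl group therefore does not keep the measurable activity seen with dimethylamino. The size of the step stays open, since compound 4 carries a limit of the assay and not a number: the limit of > 10000 nM in this assay, at which 3 of the 4 values shown sit.

As far as these compounds go, what a primary amine, diethylamino or morpholine would give on this carbon remains open. So does whether any group there would improve on compound 3, at 3500 nM.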